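Benzyl in place of hydrogen across two different linkers

The source may hold more compounds than are shown below. What is called first, only, known or untested is meant among the compounds shown, and "the series" means these compounds.

Measured compounds:
- compound 1, `C=C1C(=O)O[C@H]2[C@H]1CC/C(Cn1cc(Cn3cc(F)c(=O)[nH]c3=O)nn1)=C\CC[C@@]1(C)O[C@@H]21`: in a functional assay on Bel-7402 cells (Homo sapiens) for antiproliferative activity, read by MTT assay, with a stated time of 72 h (a lower number here means a stronger inhibitor, a higher number a weaker inhibitor), compound 1 gives > 20000 nM, which is a limit of the assay and not a number.
- compound 2, `C=C1C(=O)O[C@H]2[C@H]1CC/C(COC(=O)CCC(=O)NCCCCCCNC(=O)Cn1cc(F)c(=O)[nH]c1=O)=C\CC[C@@]1(C)O[C@@H]21`: in this assay compound 2 gives > 20000 nM, again a limit rather than a number.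
- compound 3, `C=C1C(=O)O[C@H]2[C@H]1CC/C(Cn1cc(Cn3cc(F)c(=O)n(Cc4ccccc4)c3=O)nn1)=C\CC[C@@]1(C)O[C@@H]21`: in this assay compound 3 gives 9160 nM.

The change from compound 1 to compound 3 is benzyl in place of hydrogen on an aromatic nitrogen. Going by these compounds, it gave an at least 2.1-fold lower number from compound 1 to compound 3 (0.33 log units; beyond the scatter); the size of that step is bounded only by the limit of > 20000 nM in this assay, at which 2 of the 3 values shown sit, so its true size is unknown. Compound 4, `C=C1C(=O)O[C@H]2[C@H]1CC/C(COC(=O)CCC(=O)NCCCCCCNC(=O)Cn1cc(F)c(=O)n(Cc3ccccc3)c1=O)=C\CC[C@@]1(C)O[C@@H]21`, is still to be measured in this assay. It carries the same change as compound 3, (benzyl in place of hydrogen on an aromatic nitrogen), made on the core of compound 2; the difference between the two cores is not broken down here. For the measured compounds named here, the only measured example of this change is compound 1 to compound 3, so the expectation for compound 4 rests on that single step: a step of an at least 1.6-fold lower number from compound 2 to compound 4 (0.22 log units; that floor lies within the scatter) is expected, and compound 4 is estimated at 12000 nM, within 5000 nM to 30000 nM.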

Compound 4, half-maximal inhibitory concentration: 18300 nM
Compound 4: the middle estimate sits 1.5-fold (0.18 log units) below what was measured; measured number inside the range.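

In this assay, for the compounds shown here, benzyl in place of hydrogen on an aromatic nitrogen, carried to the core of compound 2, gives an at least 1.0-fold lower number from compound 2 to compound 4 (0.03 log units; that floor lies within the scatter); this shows only that both benzyl compounds, compound 3 and compound 4, return a measured number where their hydrogen partners do not. Compound 2 gives > 20000 nM, a limit and not a number, so the true size of this step is unknown, and the same limit recurs across the series: the limit of > 20000 nM in this assay, at which 2 of the 4 values shown sit. Whether the change carries over with the same size from one core to the other is not shown: the same change on two cores in this assay, an at least 2.1-fold lower number (0.33 log units; beyond the scatter) from compound 1 to compound 3 and an at least 1.0-fold lower number (0.03 log units; that floor lies within the scatter) from compound 2 to compound 4; the limit leaves it open whether they differ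

Still open, going by these compounds, is what other groups on this aromatic nitrogen would do, for example methyl, a longer alkyl chain, or a benzyl carrying an amine or a carboxylic acid on its ring. Also open, on these data alone, is how the step behaves on a core whose hydrogen parent gives a number rather than a limit.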